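Swapping Halogens on the Aryl Tail of a Channel Activator

The compounds below may be only part of what the source reports. "The series", "measured", "known", "first", "only" and "open" are said of these compounds alone.

Of the compounds shown here, two have so far been tested in an assay on HEK293 cells for activation of Kir3.1/Kir3.2 (Homo sapiens), read by thallium flux; on this read-out lower numbers stand for an effect already at smaller amounts and higher numbers for an effect only at larger amounts of compound. Compound 1, `CCC(C)n1nc(C)cc1NC(=O)Cn1nnc(-c2ccccc2)n1`, shows only an assay limit: in this assay compound 1 gives > 5000 nM, which is a limit rather than a measured number. Among the measured compounds shown here, compound 2, `Cc1cc(NC(=O)Cn2nnc(-c3ccc(F)c(F)c3)n2)n(C2CCCCC2)n1`, is the one compound with a real number: in this assay compound 2 gives 116 nM. For the measured compounds named here, compound 2 therefore stands as the only measured value, the other result being (the limit of > 5000 nM in this assay, at which 1 of the 2 values shown sits).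

Compound 3, `Cc1cc(NC(=O)Cn2nnc(-c3ccc(Cl)c(C)c3)n2)n(C2CCCCC2)n1`, has not yet been measured. It differs from compound 2 in one place: 4-chloro-3-methylphenyl in place of 3,4-difluorophenyl on an aromatic carbon. The rest of the shared core, including the cyclohexyl group and the amide link, is unchanged. Going by the values given here, with no measured pair of this kind to lean on, the expectation is that the step from compound 2 to compound 3 in this assay stays within the usual scatter, with no clear direction, expected as a 1.3-fold higher number from compound 2 to compound 3 (0.11 log units; within the scatter). On that basis compound 3 is estimated at 150 nM in this assay, with a range from 40 nM to 600 nM.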

Compound 3, half-maximal effective concentration: 712 nM
The estimate for compound 3 lay 4.7-fold (0.68 log units) below the measured number; the whole stated range lies below it.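

In this assay, the aryl group on this five-membered aromatic ring with 4 nitrogen cannot be treated as freely exchangeable, since putting 4-chloro-3-methylphenyl in place of 3,4-difluorophenyl gives a 6.1-fold higher number from compound 2 to compound 3 (0.79 log units; beyond the scatter) while the rest of the shared core stays the same. The two groups have the same count of heavy atoms, the same carbon-only aromatic ring, no hydrogen-bond donors or acceptors and no net charge, so these simple counts do not separate the two results. Nothing measured here explains why the number moves.

This change replaces both fluorines at once, so the compounds shown cannot tell whether the chlorine, the methyl or the combination of the two accounts for the step, and a phenyl carrying only a chlorine or only a methyl would help to separate them. On these data alone, it also remains open how this position would respond to a different kind of group, such as a methoxy group, a nitrile or a pyridine ring in place of the substituted phenyl.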